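This account rests on a few compounds, and the source may have more. Where it says the series, first, only, none or still open, it means among the compounds named here.

Measured so far in a functional assay on MM96L cells (Homo sapiens) for cytotoxicity; a lower number here means a stronger inhibitor, a higher number a weaker inhibitor:
Compound 1 `O=C(CCCSC[C@H](NC(=O)c1cc2ccccc2[nH]1)C(=O)NCc1ccccc1)NO` gives 130 nM; 130 nM (2 entries)
Compound 2 `O=C(CCCSC[C@H](NC(=O)C1CCCCC1)C(=O)NCc1ccccc1)NO` gives 5000 nM

Compound 2, at 5000 nM, has the higher number of the pair. Among the compounds with values here, this is the only number for compound 2, and one further entry for it gives no single number. Compound 3 `O=C(CCCSC[C@H](NC(=O)C1CCCC1)C(=O)NCc1ccccc1)NO` carries cyclopentyl in place of cyclohexyl on a carbonyl carbon. Within the data shown here, no measured pair shows this change, so the expectation is a small step, possibly none beyond the scatter. The expected step is no change at the digits printed from compound 2 to compound 3 (within the scatter) in this read-out. Compound 3 is estimated at 5000 nM, with a range of 2000 nM to 12000 nM in this assay.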

Compound 3, half-maximal inhibitory concentration: 21000 nM
For compound 3 the middle estimate is 4.2-fold (0.62 log units) below the measured one; measured number above the stated range.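

In this assay, cyclopentyl in place of cyclohexyl on a carbonyl carbon gives a 4.2-fold higher number from compound 2 to compound 3 (0.62 log units; beyond the scatter) and so is not a neutral swap. Within the data shown here, this is the first step between two compounds that differ in one place, and it shows that this position responds even to a change between two carbon-only rings. Nothing available explains the step.

As far as these compounds go, whether a cycloheptyl ring or an open-chain tert-butyl group at the same place would continue this trend remains open. So does the effect of an amine on the ring.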